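The source may hold more compounds than are shown below. What is called first, only, known or untested is meant among the compounds shown, and "the series" means these compounds.

Among the compounds with values here, compound 1 `CC(NC(=O)/C=C/Oc1ccc(NC(=O)Nc2cc(C(F)(F)F)ccc2Cl)cc1)c1ccccc1` is the only member of this set to return a number in a functional assay on KETR3 cells (Homo sapiens) for inhibition, read by MTT assay, with a stated time of 120 h; on this read-out higher numbers stand for weaker inhibition and lower numbers for stronger inhibition: compound 1 gives 16400 nM. Compound 2 `O=C(CCc1ccc(NC(=O)Nc2ccc(Cl)c(C(F)(F)F)c2)cc1)NC1CCC1` reaches only a limit of this assay, > 50000 nM. Compound 3 `C/C(=C\c1ccc(NC(=O)Nc2ccc(Cl)c(C(F)(F)F)c2)cc1)C(=O)NC(C)c1ccccc1` likewise stops at a limit, > 50000 nM. So compound 1 stands alone with a measured value, while the other two sit at the limit of > 50000 nM in this assay, at which 2 of the 3 values shown sit. Compound 4 `CC(NC(=O)/C=C/Oc1ccc(NC(=O)Nc2ccc(Cl)c(C(F)(F)F)c2)cc1)c1ccccc1` keeps every atom of compound 1 but joins them differently: 4-chloro-3-(trifluoromethyl)phenyl in place of 2-chloro-5-(trifluoromethyl)phenyl on an amide-type nitrogen. Within the data shown here, the new pattern is the one carried by compound 2 and compound 3, whose limits give no step to lean on. Among the measured compounds shown here, with no measured step in this assay for this change, a shift beyond the scatter is not expected, and compound 4 is estimated at 12000 nM, within 3000 nM to 45000 nM, a step of a 1.4-fold lower number from compound 1 to compound 4 (0.14 log units; within the scatter).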

Compound 4, half-maximal inhibitory concentration: 14500 nM
Beside the measured number, compound 4's estimate is 1.2-fold (0.08 log units) below it; measured number inside the range.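

In this assay, 4-chloro-3-(trifluoromethyl)phenyl in place of 2-chloro-5-(trifluoromethyl)phenyl on the amide-type nitrogen gives a 1.1-fold lower number from compound 1 to compound 4 (0.05 log units; within the scatter), so rearranging these same atoms makes no difference beyond the scatter. Compound 4 also shows that a compound carrying 4-chloro-3-(trifluoromethyl)phenyl can return a number. Compound 2 and compound 3 carry that group too, yet each differs from compound 4 in more than one place and each remains at a limit: the limit of > 50000 nM in this assay, at which 2 of the 4 values shown sit.

Open, on these data alone, is whether a phenyl ring bearing a nitrile or an amine on this nitrogen would move the number beyond the scatter.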